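A few compounds are considered here, and "the series" means these few. Any claim that something is new, unique, unknown or untested is made for them only; others in the source may bear on it.

Working notes on the series. In an ADME assay on microsomes from liver (Homo sapiens) for metabolic stability, with a stated time of 10 min, tested at 0.5 uM (a higher number here means that more of the compound is left, a lower number that less of the compound is left), compound 1 (`Cn1cc(-c2ccc(C(F)(F)F)cc2)c2cc(F)c(C(=O)NS(=O)(=O)C3CC3)cc21`) gives 100% and compound 2 (`CC(C)COc1ccc(-c2nn(C)c3cc(C(=O)NS(=O)(=O)C4CC4)c(F)cc23)cn1`) gives 91% while compound 3 (`CC(C)COc1ncc(-c2nn(C)c3cc(C(=O)NS(C)(=O)=O)ccc23)cc1Cl`) gives 100% so compound 1 stands within the scatter of both others. Compound 4 (`Cn1cc(-c2ccc(C(F)(F)F)cc2)c2ccc(C(=O)NS(=O)(=O)C3CC3)cc21`) differs from compound 1 by hydrogen in place of fluoro on an aromatic carbon in one place: hydrogen in place of fluoro on an aromatic carbon, ortho to a (cyclopropylsulfonyl)carbamoyl group. Among the compounds with values here, no measured pair isolates this change, so the expectation in this assay rests only on the three close values, and no step beyond the scatter is expected. The expected step is a number 4 percentage points lower from compound 1 to compound 4 (within the scatter) and it stays within the scatter. For compound 4 the estimate is 96% with 84% to 100% as the expected range.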

Compound 4, percent of the compound remaining: 87%
The estimate for compound 4 lay 9 percentage points above the measured number, within the range that was stated.
By their numbers in this assay, from the lowest: compounds 4, 2, 1 and 3 (each within the scatter of the next, the first and the last beyond it).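

In this assay, the first pair differing in one place gives a number 13 percentage points lower from compound 1 to compound 4 (beyond the scatter) and so shows that this exchange, on an aromatic carbon ortho to a (cyclopropylsulfonyl)carbamoyl group, can carry a modest step beyond the scatter. The reading rests on this single pair and holds for this core only. No evidence on hand bears on the origin of the step.

On these data alone, what a chloro, methyl or methoxy group would give at this position stays open. As far as these compounds go, whether the same exchange gives a similar step on the cores of compound 2 and compound 3 also stays open.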